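The source may hold more compounds than are shown below. What is called first, only, known or untested is meant among the compounds shown, and "the series" means these compounds.

Measured so far, all in a functional assay on cells (Leukemia cell, Homo sapiens) for inhibition; a lower number here means a stronger inhibitor of growth, a higher number a weaker inhibitor of growth:
compound 1, `N#CSc1c(-c2ccccc2)nc2sc(Cc3ccccc3)nn12`, gives 13500 nM
compound 2, `COc1ccc(-c2nc3sc(Cc4ccccc4)nn3c2SC#N)cc1`, gives 3600 nM
compound 3, `O=Cc1c(-c2ccc([N+](=O)[O-])cc2)nc2sc(Cc3ccccc3)nn12`, gives 5900 nM

Among these three numbers, compound 3 holds the second highest. Its nearest neighbour is compound 2, and the two lie within the usual scatter of each other, so no order can be read between them. Compound 1 stands further off, with a number higher than that of compound 3 by a margin beyond the scatter. Going by the values given here, the only step between two compounds that differ in a single place is a 3.8-fold lower number from compound 1 to compound 2 (0.57 log units; beyond the scatter), a modest change brought about by a methoxy in place of hydrogen on an aromatic carbon.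

Compound 4, `O=[N+]([O-])c1ccc(-c2nc3sc(Cc4ccccc4)nn3c2Br)cc1`, has not yet been measured. It differs from compound 3 by bromo in place of formyl on an aromatic carbon. Among the compounds with values here, no measured pair shows what such an exchange does: the step from compound 1 to compound 2 concerns a different part of the molecule, and compounds 1 and 2 each differ from compound 3 in two places at once, so their values show only that all three numbers sit in a fairly narrow band. With nothing to anchor the change, the expectation for compound 4 is no step beyond the scatter, no change at the digits printed from compound 3 to compound 4 (within the scatter). Compound 4 is therefore estimated at 5900 nM in this assay, with a range from 2000 nM to 18000 nM.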

Compound 4, concentration for 50% growth inhibition: 69200 nM
For compound 4 the middle estimate is 12-fold (1.07 log units) below the measured one; measured number outside the range, above it.
By their numbers in this assay, from the lowest: compounds 2 and 3 (each within the scatter of the next); then compound 1; then compound 4.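

In this assay bromo in place of formyl on this aromatic carbon gives a 12-fold higher number from compound 3 to compound 4 (1.07 log units; beyond the scatter) and so marks a large step. Going by these compounds alone, this shows that the number depends strongly on the group at this place on the five-membered aromatic ring, something the only earlier step, a 3.8-fold lower number from compound 1 to compound 2 (0.57 log units; beyond the scatter) and a modest one in another part of the molecule, could not show. Nothing given here explains why this exchange has so large an effect.

Going by these compounds, only formyl and bromo can be compared directly at this place, so it stays open whether the step reflects losing formyl or gaining bromo. On these data alone, whether hydrogen, chloro, an amine or a carboxylic acid here would give a number close to compound 3 or close to compound 4 also remains unknown.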